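A few compounds are considered here, and "the series" means these few. Any claim that something is new, unique, unknown or untested is made for them only; others in the source may bear on it.

Measured in a functional assay on PC-3 cells (Homo sapiens) for antiproliferative activity; on this read-out lower numbers stand for stronger inhibition of growth and higher numbers for weaker inhibition of growth:
- Compound 1 `c1ccc(-c2cc(-c3cccnc3)nc(-c3ccccn3)c2)cc1`: 0.28 ug/mL
- Compound 2 `c1ccc(-c2cc(-c3ccoc3)cc(-c3ccccn3)n2)nc1`: 0.0044 ug/mL

Of these two compounds, compound 1 has the higher number, at 0.28 ug/mL, which marks the weaker growth inhibition in this assay. Compound 2 gives 0.0044 ug/mL, and the gap between the two compounds lies well beyond the scatter.

The next compound, compound 3 `c1ccc(-c2cc(-c3cccs3)cc(-c3cccnc3)n2)nc1`, has thiophen-2-yl in place of phenyl on an aromatic carbon, opposite the ring nitrogen: thiophen-2-yl in place of phenyl on an aromatic carbon. Among the measured compounds shown here, no measured pair isolates this change, so the expectation rests on little. Numbers far lower than that of compound 1 do occur here, as compound 2 shows at 0.0044 ug/mL, so a moderate move toward a lower number is expected, and a step within the scatter cannot be excluded. The estimated change is a 3.5-fold lower number from compound 1 to compound 3 (0.54 log units; beyond the scatter). Compound 3 is expected at 0.08 ug/mL, with an estimated range of 0.01 ug/mL to 0.5 ug/mL.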

Compound 3, concentration for 50% growth inhibition: 0.031 ug/mL
For compound 3 the middle estimate is 2.6-fold (0.41 log units) above the measured one; the range from low to high includes it.
By their numbers in this assay, from the lowest: compound 2; then compound 3; then compound 1.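

With compound 3, the position opposite the ring nitrogen gets its first isolated change: in this assay, thiophen-2-yl in place of phenyl gives a 9.0-fold lower number from compound 1 to compound 3 (0.96 log units; beyond the scatter). This shows that growth inhibition depends on which ring this aromatic carbon carries, and that a five-membered aromatic ring with one sulfur atom is tolerated there, with a lower number than the phenyl of compound 1 gives. Nothing measured explains the step.

As far as these compounds go, it remains open whether the sulfur-bearing ring itself matters, or whether thiophen-3-yl, a simple amine or a piperidine ring at this carbon would give a similar number. This single pair also leaves open whether the step would hold with the pyridin-2-yl or pyridin-3-yl group replaced.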